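Swapping a dichloropyridine for a dichlorophenyl urea

The source may hold more compounds than are shown below. What is called first, only, known or untested is meant among the compounds shown, and "the series" means these compounds.

Four compounds share a theme of two chlorine atoms on an aromatic ring joined through a carbonyl. Compound 1 `Cc1cc(C#N)nc(NNC(=O)Nc2cc(Cl)nc(Cl)c2)c1` was tested in a functional assay on CHO cells for antagonist activity at sphingosine 1-phosphate receptor 2 (Homo sapiens), read by fluorescence and calcium flux, with a stated time of 3 min (a lower number here means a stronger inhibitor, a higher number a weaker inhibitor), and returned only a limit of the method, > 6600 nM, rather than a number. Going by the values given here, compound 2 `Cc1cc(CNC(=O)c2cc3c(Cl)nc(Cl)cc3[nH]2)ncc1-c1cn(C)nc1C` is the one member with a measured value, giving 890 nM in this assay. Compound 3 `Cc1cc(CNC(=O)c2cc(Cl)nc(Cl)c2)ncc1-c1cn(C)nc1C` likewise gave only a limit in this assay, reported as > 19000 nM. So compound 3 stands at the upper edge of what the method can report, described by the limit of > 19000 nM in this assay, at which 1 of the 3 values shown sits, while compound 1 sits at another limit, (the limit of > 6600 nM in this assay, at which 1 of the 3 values shown sits); neither can be ranked against the other.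

Compound 4 `Cc1cc(CNC(=O)Nc2cc(Cl)cc(Cl)c2)ncc1-c1cn(C)nc1C` has not yet been tested. It differs from compound 3 in one place: (3,5-dichlorophenyl)amino in place of 2,6-dichloropyridin-4-yl on a carbonyl carbon, turning an amide into a urea. Among the compounds with values here, no measured pair tracks this change, so the expected step of an at least 2.3-fold lower number from compound 3 to compound 4 (0.37 log units; beyond the scatter) is uncertain and is not expected to reach the range of compound 2. For compound 4 the estimated value in this assay is 8000 nM, within 1500 nM to 40000 nM, with a fair chance that only a limit is reported.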

Compound 4, half-maximal inhibitory concentration: 160 nM
Compound 4: the middle estimate sits 50-fold (1.70 log units) above what was measured; measured number below the stated range.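

At this place on the carbonyl carbon, putting (3,5-dichlorophenyl)amino in place of 2,6-dichloropyridin-4-yl has a large effect in this assay, with an at least 110-fold lower number from compound 3 to compound 4 (2.07 log units; beyond the scatter). This is the first pair shown that differs in only one place, so it is the first direct sign that the group on this carbonyl carbon can decide whether a compound reaches a measurable number, such as compound 4 at 160 nM. The true size of the step stays unknown and could be larger, because compound 3 has no exact number, only a limit: the limit of > 19000 nM in this assay, at which 1 of the 4 values shown sits.

The change alters several things at once: a ring of carbon only replaces a ring with a hetero atom, a hydrogen-bond donor enters, and an amide becomes a urea, so this single pair cannot say which of these matters. An amide carrying a plain 3,5-dichlorophenyl group on the carbonyl carbon would help pull these apart, and methoxy groups in place of the two chlorines would test whether the chlorines are needed at all.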